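A Nitro Group Replaces Chloro in an Inactive Series

This account rests on a few compounds, and the source may have more. Where it says the series, first, only, none or still open, it means among the compounds named here.

Measured in a functional assay on HT-29 cells (Homo sapiens) for inhibition, read by sulforhodamine B assay, with a stated time of 48 h; a higher number here means a weaker inhibitor of growth, a lower number a stronger inhibitor of growth:
- compound 1 `CCOC(=O)c1nn(-c2ccc(Cl)cc2)c(-c2ccc(Cl)cc2)c1CNC(C)(C)C`: 57700 nM; > 519000 nM (2 entries)
- compound 2 `CC(C)(C)NCc1c(C(=O)O)nn(-c2ccc(Cl)cc2)c1-c1ccc(Cl)cc1`: > 599000 nM

Compound 1 has two entries in this assay, one a number and the other a limit, as shown by the several entries of compound 1 in this assay, 57700 nM; > 519000 nM (2 entries). Compound 2 has no single number. For the measured compounds named here, its only reported value, > 599000 nM, is a limit of the assay.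

The next compound to be tested is compound 3 `CC(C)(C)NCc1c(C(=O)O)nn(-c2ccc(Cl)cc2)c1-c1ccc([N+](=O)[O-])cc1`. It keeps the core of compound 2 but carries nitro in place of chloro on an aromatic carbon, para to a large group, so that one 4-chlorophenyl becomes 4-nitrophenyl (nitro in place of chloro on an aromatic carbon). Going by the values given here, no measured pair in this set shows what such a change does. No step beyond the scatter is therefore expected in this assay, and another limit is the most likely result. Compound 2 gives the only reference point for this expectation, with its limit of > 599000 nM. The expected step is an at least 1.0-fold lower number from compound 2 to compound 3 (0.03 log units; that floor lies within the scatter). For compound 3 the estimated value is 550000 nM, with an expected range from 150000 nM to 1000000 nM.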

Compound 3, concentration for 50% growth inhibition: > 583000 nM
Compound 3 ended at the assay's limit (the forecaster's own chance of this, stated with the estimate: 70%); at least 1.0-fold (0.02 log units) between middle value and limit.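

In this assay compound 3 gives > 583000 nM, which is a limit of the assay. Compound 2 gives > 599000 nM, also a limit. No step can be read between compound 2 and compound 3. The compounds shown leave open whether nitro in place of chloro changes growth inhibition at all on this core.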